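The compounds below may be only part of what the source reports. "The series", "measured", "known", "first", "only" and "open" are said of these compounds alone.

The measured compounds in an assay on IMR-32 cells for displacement of a labelled ligand from corticotropin-releasing factor receptor 1 (Homo sapiens), read by scintillation counting, with a stated time of 2 h; on this read-out lower numbers stand for stronger inhibition and higher numbers for weaker inhibition:

Compound 1, `CCC(CC)Nc1nc(OC)c(-c2ccc(Cl)cc2Cl)nc1C`: 14.4 nM
Compound 2, `CCc1nc(NC(CC)CC)c(Cl)nc1-c1ccc(Cl)cc1Cl`: 71 nM
Compound 3, `CCc1nc(-c2ccc(Cl)cc2Cl)c(CC)nc1NC(C1CC1)C1CC1`: 3.7 nM

Of these three, compound 3 has the lowest number. Compound 1, at 14.4 nM, lies beyond the scatter from it. Compound 2, at 71 nM, lies further away still, also beyond the scatter. Going by the values given here, each of the three measured compounds carries a branched amino substituent on the shared core, so the set offers no step in which that amino group is exchanged for anything else.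

Compound 4, `CCc1nc(-c2ccc(Cl)cc2Cl)c(CC)nc1CC(CC)CC`, makes exactly such an exchange: 2-ethylbutyl in place of (dicyclopropylmethyl)amino on an aromatic carbon. Because compound 3 gives 3.7 nM while carrying the amino group that compounds 1 and 2 also carry, the account can lean only on the nature of the change, not on a measured precedent. Removing the hydrogen-bond donor and acceptor and the two rings is the kind of change that, in the writer's estimation, is expected to weaken binding by a margin beyond the scatter rather than leave it unchanged. The step of an 11-fold higher number from compound 3 to compound 4 (1.03 log units; beyond the scatter) is therefore expected to run toward a higher number. For compound 4 the estimate is 40 nM, with a range from 8 nM to 200 nM.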

Compound 4, inhibition constant: 68 nM
Compound 4: the middle estimate sits 1.7-fold (0.23 log units) below what was measured, within the range that was stated.
By their numbers in this assay, from the lowest: compound 3; then compound 1; then compounds 4 and 2 (each within the scatter of the next).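

In this assay, putting 2-ethylbutyl in place of (dicyclopropylmethyl)amino on the aromatic carbon next to the ring nitrogen gives an 18-fold higher number from compound 3 to compound 4 (1.26 log units; beyond the scatter), a large step beyond the scatter. The earlier compounds all carry a branched amino substituent, so this is the first exchange of that group in the compounds shown, and it shows that the number in this assay responds strongly to what stands at this position, while compound 4 still gives a measured 68 nM with no nitrogen in the entering group. The exchange removes the two three-membered rings, the hydrogen-bond donor and the hydrogen-bond acceptor in a single step, and nothing measured here says which of these changes accounts for the shift.

On these data alone, what a (1-ethylpropyl)amino group, or a dicyclopropylmethyl group attached directly through carbon, would give on the core of compound 3 remains open, and with it whether the step follows the amino nitrogen or the two rings. As far as these compounds go, an ether such as 1-ethylpropoxy on the same carbon is an equally open case.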